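Chloro on the pyridine of a fused diamine core

The source may hold more compounds than are shown below. What is called first, only, known or untested is meant among the compounds shown, and "the series" means these compounds.

Measured so far:
Compound 1, `Brc1cncc(N2CC[C@H]3CN[C@H]3C2)c1`: 150 nM
Compound 2, `Clc1cc(N2CC[C@H]3CN[C@H]3C2)cnc1Cl`: 12 nM
Compound 3, `c1cncc(N2C[C@H]3CCNC[C@H]32)c1`: 1400 nM

In a functional assay on HEK293 cells for agonist activity at Neuronal acetylcholine receptor; alpha4/beta2 (Homo sapiens), read by FLIPR (a lower number here means that less compound is needed, a higher number that more compound is needed for the effect), compound 3 gives 1400 nM, the highest of the three numbers: compound 1 sits well below it, and compound 2 lies furthest away, far below it. Compound 3 carries an unsubstituted pyridine on its core, whereas compound 1 and compound 2 both carry halogens on theirs, though their cores differ from that of compound 3, so none of these pairs forms a single-change step.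

Compound 4, `Clc1ccc(N2C[C@H]3CCNC[C@H]32)cn1`, is obtained from compound 3 by chloro in place of hydrogen on an aromatic carbon, next to the ring nitrogen and para to a group of 8 heavy atoms. Among the compounds with values here, no measured pair shows exactly this change, so the expectation rests on the picture as a whole: the two halogenated compounds, compound 1 with 150 nM and compound 2 with 12 nM, sit below compound 3. Compound 4 is therefore expected to come in below compound 3, by a step beyond the scatter but short of the gap to compound 2; the estimated step is a 7.0-fold lower number from compound 3 to compound 4 (0.85 log units; beyond the scatter). For compound 4 the estimated value in this assay is 200 nM, with a likely range from 40 nM to 1000 nM.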

Compound 4, half-maximal effective concentration: 216 nM
The estimate for compound 4 lay 1.1-fold (0.03 log units) below the measured number; low and high end bracket the measured number.
By their numbers in this assay, from the lowest: compound 2; then compounds 1 and 4 (each within the scatter of the next); then compound 3.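

In this assay, placing chloro in place of hydrogen on an aromatic carbon, next to the ring nitrogen and para to a group of 8 heavy atoms, gives a 6.5-fold lower number from compound 3 to compound 4 (0.81 log units; beyond the scatter), a step beyond the scatter. Within the data shown here, this is the only pair here that differs in one place, so the change in number can be tied directly to this chloro on this core, whereas the halogens of compound 1 and compound 2 come with a different core and could not be separated from it. Nothing available explains why this chloro lowers the number.

The compounds shown cover a single substituent at a single place, so it remains open whether a fluoro, a methyl, a methoxy or an amine at this same position would move the number by more, by less or in the other direction. As far as these compounds go, it also remains open whether chloro at another carbon of the pyridine would give a similar step, or whether this step carries over to the core of compound 1 and compound 2.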